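This account rests on a few compounds, and the source may have more. Where it says the series, first, only, none or still open, it means among the compounds named here.

Compound 1 `COc1cccc(C(=O)Nc2ccc(Cl)cc2CN2C(=O)c3ccccc3C2=O)c1` was tested in an assay on CHO cells for positive allosteric modulation of metabotropic glutamate receptor 5 (Homo sapiens), read by FLIPR (a higher number here means that more compound is needed for the effect, a lower number that less compound is needed), where compound 1 gives 1500 nM. Among the compounds with values here, this is the lower of the two numbers known so far; compound 2 `O=C(Nc1ccccc1CN1C(=O)c2ccccc2C1=O)c1ccccn1` gives 13900 nM, a weaker result. Compound 3 `O=C(Nc1ccc(Cl)cc1CN1C(=O)c2ccccc2C1=O)c1cccnn1` has not yet been measured. It differs from compound 1 in one place: pyridazin-3-yl in place of 3-methoxyphenyl on a carbonyl carbon. Within the data shown here, no measured pair covers exactly this change, and compound 2 differs from compound 1 in more than this one place, so only a loose expectation is possible. A somewhat weaker result is expected, with a step of a 2.7-fold higher number from compound 1 to compound 3 (0.43 log units; beyond the scatter). For compound 3 the estimate is 4000 nM, with a range from 1500 nM to 12000 nM.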

Compound 3, half-maximal effective concentration: > 100000 nM
Compound 3: a limit, no number (the forecaster's own chance of this, stated with the estimate: 10%); at least 25-fold (1.39 log units) between middle value and limit.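

Replacing 3-methoxyphenyl with pyridazin-3-yl on the carbonyl carbon, with the rest of compound 1 unchanged, gives in this assay an at least 66-fold higher number from compound 1 to compound 3 (1.82 log units; beyond the scatter), so this position does not accept every six-membered aromatic ring alike. Compound 3 gives a limit of the assay and not a number: the limit of > 100000 nM in this assay, at which 1 of the 3 values shown sits. The full size of this step therefore cannot be read.

The change removes the methoxy group and brings in ring nitrogens at once, and the compounds shown cannot tell which of these matters. A plain phenyl or a 3-hydroxyphenyl group at this place would help to separate the two.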